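Phenyl to Methyl Across Two Cores: Cytotoxicity Limits

The source may hold more compounds than are shown below. What is called first, only, known or untested is meant among the compounds shown, and "the series" means these compounds.

Three compounds were run in an ADME assay on L929 cells (Mus musculus) for cytotoxicity, read by resazurin assay, with a stated time of 72 h; on this read-out higher numbers stand for weaker inhibition and lower numbers for stronger inhibition. Compound 1 `O=C(NCc1ccccc1)c1cccn1-c1ccc2c(c1)B(O)OC2` returns only the assay limit, > 10 ug/mL. Compound 2 `CCNC(=O)c1cccn1-c1ccc2c(c1)B(O)OC2` likewise sits at the limit, > 10 ug/mL. Compound 3 `O=C(CCc1ccccc1)c1ccn(-c2ccc3c(c2)B(O)OC3)c1` also gives only a limit, > 10 ug/mL. The change from compound 1 to compound 2 is methyl in place of phenyl on a saturated chain carbon bound to an amide-type nitrogen, and a step that the two limits leave unreadable from compound 1 to compound 2, since both values rest at the limit of > 10 ug/mL in this assay, at which 3 of the 3 values shown sit.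

Compound 4 `CCCC(=O)c1ccn(-c2ccc3c(c2)B(O)OC3)c1` stands to compound 3 as compound 2 stands to compound 1: methyl in place of phenyl on a saturated chain carbon, two bonds along the chain from a carbonyl carbon. The place differs, though: in compound 1 the carbon is bound to an amide-type nitrogen, in compound 3 it lies two bonds along the chain from a carbonyl carbon, so this is the same kind of change, not the same change. The difference between the two cores is not broken down here. Resting on the step that the two limits leave unreadable from compound 1 to compound 2, compound 4 is expected to show a change of a step that the limit leaves unreadable from compound 3 to compound 4. Compound 4 is thus estimated at 15 ug/mL, between 8 ug/mL and 40 ug/mL.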

Compound 4, half-maximal inhibitory concentration: > 10 ug/mL
Compound 4 gave a limit, no number (the forecaster's own chance of this, stated with the estimate: 80%); the middle value is on the limit's open side.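

No step can be read from compound 3 to compound 4, as both give only a limit: the limit of > 10 ug/mL in this assay, at which 4 of the 4 values shown sit.

The compounds shown leave open whether phenyl or methyl changes the result in this assay at either place.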